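Replacing hydroxymethyl with dimethylcarbamoyl in compound 1

The compounds below may be only part of what the source reports. "The series", "measured", "known", "first", "only" and "open" are said of these compounds alone.

In an ADME assay on microsomes from liver (Homo sapiens) for metabolic stability, read by LC-MS, using NADPH, with stated times of 5 min and 30 min, tested at 1 uM (on this read-out higher numbers stand for fast clearance and lower numbers for slow clearance), compound 1 `Cc1nc(CO)ccc1-c1cnc(NCc2c(F)ccc3c2CCO3)c2cn[nH]c(=O)c12` gives 11 mL.min-1.g-1 and stands level, within the scatter, with compound 2 `Cc1ncc(-c2cnc(NCc3c(F)ccc4c3CCO4)c3cn[nH]c(=O)c23)n1C` at 10 mL.min-1.g-1 on the numbers shown. Compound 3 `CNC(=O)c1cc(-c2cnc(NCc3c(F)ccc4c3CCO4)c3cn[nH]c(=O)c23)n(C)n1` is reported as < 3 mL.min-1.g-1 and this is a limit of the assay, not a number.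

Compound 4 `Cc1nc(C(=O)N(C)C)ccc1-c1cnc(NCc2c(F)ccc3c2CCO3)c2cn[nH]c(=O)c12` keeps the core of compound 1 and its methyl group, and carries dimethylcarbamoyl in place of hydroxymethyl on an aromatic carbon, next to the ring nitrogen (dimethylcarbamoyl in place of hydroxymethyl on an aromatic carbon). Within the data shown here, no measured step changes this group alone. The nearest steps exchange the entire group on the core. With 1,2-dimethyl-1H-imidazol-5-yl the result is a 1.1-fold lower number from compound 1 to compound 2 (0.04 log units; within the scatter) and so no real change. With 1-methyl-3-(methylcarbamoyl)-1H-pyrazol-5-yl the result is an at least 3.6-fold lower number from compound 1 to compound 3 (0.56 log units; beyond the scatter) and the same exchange starting from the imidazole gives an at least 3.3-fold lower number from compound 2 to compound 3 (0.52 log units; beyond the scatter) as well. Among the measured compounds shown here, compound 3 is the only measured compound with a carbamoyl group, so it points only weakly towards a lower number for compound 4, which keeps the six-membered ring of compound 1. In this assay no step beyond the scatter is expected, and the estimated change is a 1.4-fold lower number from compound 1 to compound 4 (0.14 log units; within the scatter) and so stays small. The value expected for compound 4 is 8 mL.min-1.g-1 (estimated range 3.5 mL.min-1.g-1 to 18 mL.min-1.g-1).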

Compound 4, intrinsic clearance in microsomes: 19 mL.min-1.g-1
Beside the measured number, compound 4's estimate is 2.4-fold (0.38 log units) below it; the measured number lies above the stated range.
By their numbers in this assay, from the lowest: compounds 2, 1 and 4 (each within the scatter of the next). At a limit, below all of these: compound 3.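

In this assay, putting dimethylcarbamoyl in place of hydroxymethyl gives a 1.7-fold higher number from compound 1 to compound 4 (0.24 log units; within the scatter), so this exchange, on an aromatic carbon next to the ring nitrogen, leaves the read-out within the scatter. The earlier steps shown here exchanged the entire group on the core, whereas this one alters only the substituent on the six-membered aromatic ring with 1 nitrogen, and it shows that a larger group without a hydrogen-bond donor can stand at this place with no step beyond the scatter; on this ring, then, a carbamoyl group does not by itself bring a real change in clearance. Nothing measured here gives a cause for this step.

The compounds shown leave open whether an aminomethyl group, a carboxylic acid or a longer chain such as hydroxyethyl at this place would move the number beyond the scatter, in either direction. They also leave open whether the limit reported for compound 3 goes with its methylcarbamoyl group or with its five-membered ring, since those two features change together there.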